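Swapping a methylphenyl for a pyridinyl on a sulfonamide core

A few compounds are considered here, and "the series" means these few. Any claim that something is new, unique, unknown or untested is made for them only; others in the source may bear on it.

Compound 1 `COc1ccc(Cl)cc1S(=O)(=O)Nc1cncc(C(=O)Nc2ccccc2)c1` gives 310 nM in an assay on isolated protein for inhibition of alkaline phosphatase, tissue-nonspecific isozyme (Homo sapiens); on this read-out higher numbers stand for weaker inhibition and lower numbers for stronger inhibition.
Compound 2 `COc1ccc(Cl)cc1S(=O)(=O)Nc1cncc(-c2cccc(C)c2)c1` gives 160 nM in this assay.

Compound 2 stands next to compound 1 on these numbers; the step of a 1.9-fold lower number from compound 1 to compound 2 (0.29 log units; within the scatter) lies within the scatter, so the two cannot be ordered. Compound 3 `COc1ccc(Cl)cc1S(=O)(=O)Nc1cncc(-c2ccncc2)c1` differs from compound 2 in one place: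
pyridin-4-yl in place of 3-methylphenyl on an aromatic carbon
Within the data shown here, the only measured step, a 1.9-fold lower number from compound 1 to compound 2 (0.29 log units; within the scatter), exchanges a different group at that carbon and does not involve a ring bearing a nitrogen, so no measured step bears directly on this change. Compound 3 is therefore expected to move by a 1.6-fold higher number from compound 2 to compound 3 (0.19 log units; within the scatter) at most, nothing beyond the scatter. Compound 3 is estimated at 250 nM, in the range 80 nM to 800 nM.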

Compound 3, half-maximal inhibitory concentration: 73 nM
Compound 3: middle estimate off by 3.4-fold (0.53 log units), on the high side; measured number outside the range, below it.
By their numbers in this assay, from the lowest: compound 3; then compounds 2 and 1 (each within the scatter of the next).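

At this aromatic carbon, the change gives a step beyond the scatter in this assay, a 2.2-fold lower number from compound 2 to compound 3 (0.34 log units; beyond the scatter), with pyridin-4-yl entering for 3-methylphenyl. The same group also separates from phenylcarbamoyl, a 4.2-fold lower number from compound 1 to compound 3 (0.63 log units; beyond the scatter), although the two groups in compound 1 and compound 2 could not be ordered. Nothing given here accounts for these steps. On these data alone, it remains open whether pyridin-3-yl, with its ring nitrogen placed differently, would match pyridin-4-yl. Also open, as far as these compounds go, is how an amine or a carboxylic acid on this ring would read.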